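The source may report more compounds than this note shows. Statements on the series, on what has been measured and on what is new or still open speak of the compounds shown alone.

In a functional assay on KYSE-70 cells for antiproliferative activity against KYSE-70 cell line (Homo sapiens), read by MTT assay, with a stated time of 72 h (a lower number here means a stronger inhibitor, a higher number a weaker inhibitor), compound 1 `O=C(Nc1cccc(C(F)(F)F)c1)c1cc(=O)[nH]c2cc(Br)ccc12` gives only the limit of > 20000 nM and no number. Compound 2 `CC(=O)c1ccc(-c2ccc3c(C(=O)Nc4cccc(F)c4)cc(=O)[nH]c3c2)cc1` likewise gives only the limit of > 20000 nM in this assay. Compound 2 therefore stands at the limit, the same place as both values shown, as the limit of > 20000 nM in this assay, at which 2 of the 2 values shown sit, records. Compound 3 `O=C(Nc1cccc(F)c1)c1cc(=O)[nH]c2cc(C3=CCOCC3)ccc12` differs from compound 2 by a group of 6 heavy atoms (5 carbon, 1 oxygen; one six-membered non-aromatic ring with 1 hetero atom) in place of a group of 9 heavy atoms (8 carbon, 1 oxygen; one six-membered aromatic ring of carbon only), on an aromatic carbon. Going by the values given here, no measured step between the two exists, so the step expected from compound 2 to compound 3 is a number no higher from compound 2 to compound 3 (the limit leaves the size open), none beyond the scatter. Compound 3 is accordingly estimated at 20000 nM, within 7000 nM to 60000 nM, most probably again reported only as a limit.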

Compound 3, half-maximal inhibitory concentration: 10500 nM
Beside the measured number, compound 3's estimate is 1.9-fold (0.28 log units) above it; low and high end bracket the measured number.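

At this aromatic carbon, putting the six-membered non-aromatic ring with 1 hetero atom in place of 4-acetylphenyl gives an at least 1.9-fold lower number from compound 2 to compound 3 (0.27 log units; that floor lies within the scatter) in this assay. Compound 3 is thus the only compound shown with a number rather than a limit, so this position can carry a measurable value, though a weak one. The reading for compound 2 remains a limit, so the true size of the step stays unknown: the limit of > 20000 nM in this assay, at which 2 of the 3 values shown sit.

The compounds shown leave open whether a piperidine ring or a carboxylic acid at this carbon would lower the number further. They also leave open how the amide's 3-fluorophenyl part contributes.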